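The compounds below may be only part of what the source reports. "The series", "measured", "known", "first", "only" and "open" are said of these compounds alone.

Working notes on the series. In a functional assay on HEK293 cells for agonist activity at prostaglandin E2 receptor EP2 subtype (Rattus norvegicus), read by cAMP accumulation (a lower number here means that less compound is needed, a higher number that more compound is needed for the effect), compound 1 `CCCCc1ccc(CN(c2ccccc2CCCC(=O)O)S(C)(=O)=O)cc1` gives 103 nM, and compound 2 `CCCCC(O)c1ccc(CN(CCCCCCC(=O)O)S(C)(=O)=O)cc1` gives 423 nM, the higher of the two numbers available; the gap between compound 1 and compound 2 lies beyond the scatter. Compound 3 `CCCCc1ccc(CN(c2cccc(CCC(=O)O)c2)S(C)(=O)=O)cc1` stands in this assay at "not determined" (no result reported), so no number is available for it. Compound 4 `CCCCCC(=O)c1ccc(CN(CCCCCCC(=O)O)S(C)(=O)=O)cc1` is unmeasured. It differs from compound 2 in one place: pentylcarbonyl in place of 1-hydroxypentyl on an aromatic carbon. The hydrogen-bond donor of the 1-hydroxypentyl group is lost and one hydrogen-bond acceptor remains. For the measured compounds named here, no measured pair in this set tracks this change, so the expected step from compound 2 to compound 4 in this assay is a 1.2-fold higher number from compound 2 to compound 4 (0.07 log units; within the scatter), judged to be none beyond the scatter. Compound 4 is therefore estimated at 500 nM, within 150 nM to 1700 nM.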

Compound 4, half-maximal effective concentration: 887 nM
Compound 4: middle estimate off by 1.8-fold (0.25 log units), on the low side; the range from low to high includes it.
By their numbers in this assay, from the lowest: compound 1; then compound 2; then compound 4.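

For the compounds shown here, on the aromatic carbon para to a large group, pentylcarbonyl in place of 1-hydroxypentyl provides the first single-place comparison: in this assay it gives a 2.1-fold higher number from compound 2 to compound 4 (0.32 log units; beyond the scatter) and shows that this position responds to the change. The step accompanies the loss of the hydrogen-bond donor, but a single pair cannot tie the two together. No available evidence bears on what lies behind the step.

Still open, from the compounds shown here alone, is how a plain pentyl or a 1-aminopentyl group would compare at this position. Also open, going by these compounds, is whether the same change would give a similar step on the core of compound 1.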